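Aryl Substituent Variation on a Triazole-Linked Bicyclic Lactam

This account rests on a few compounds, and the source may have more. Where it says the series, first, only, none or still open, it means among the compounds named here.

Compound 1 `Cc1ccccc1-n1cc(CN2C(=O)C[C@@H]3CC[C@@]2(C)C3(C)C)nn1` — 150 nM
Compound 2 `CC1(C)[C@H]2CC[C@]1(C)N(Cc1cn(-c3ccccc3O)nn1)C(=O)C2` — 120 nM
Compound 3 `CC1(C)[C@H]2CC[C@]1(C)N(Cc1cn(-c3ccccc3)nn1)C(=O)C2` — 90 nM

In a functional assay on HepG2 cells (Homo sapiens) for inhibition, read by MTT assay, with a stated time of 24 h (on this read-out lower numbers stand for stronger inhibition and higher numbers for weaker inhibition), compound 1 gives 150 nM, the highest of the three numbers, though its steps to compound 2 and compound 3 both stay within the scatter: a 1.3-fold lower number from compound 1 to compound 2 (0.10 log units; within the scatter) and a 1.7-fold lower number from compound 1 to compound 3 (0.22 log units; within the scatter). The step from compound 2 to compound 3 is likewise small, a 1.3-fold lower number from compound 2 to compound 3 (0.12 log units; within the scatter). The three measured compounds therefore behave alike in this assay.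

Compound 4 `CC1(C)[C@H]2CC[C@]1(C)N(Cc1cn(-c3cccc(Br)c3)nn1)C(=O)C2` differs from compound 1 in one place: 3-bromophenyl in place of 2-methylphenyl on an aromatic nitrogen. Within the data shown here, none of the measured steps introduces bromine, so the closest comparisons are the two changes at the same phenyl ring, hydroxy in place of methyl and hydrogen in place of methyl, both of which moved the number by less than the scatter. On that basis compound 4 is expected to stay close to compound 1, with an estimated step of a 1.3-fold lower number from compound 1 to compound 4 (0.10 log units; within the scatter) and no change beyond the scatter in either direction. The estimate for compound 4 is 120 nM, within a range from 55 nM to 260 nM.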

Compound 4, half-maximal inhibitory concentration: 20 nM
Compound 4: the middle estimate sits 6.0-fold (0.78 log units) above what was measured; measured number outside the range, below it.
By their numbers in this assay, from the lowest: compound 4; then compounds 3, 2 and 1 (each within the scatter of the next).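

In this assay, the aryl group on the aromatic nitrogen can move the number beyond the scatter, which the earlier changes on this ring did not show: 3-bromophenyl in place of 2-methylphenyl gives a 7.5-fold lower number from compound 1 to compound 4 (0.88 log units; beyond the scatter), and 3-bromophenyl in place of 2-hydroxyphenyl gives a 6.0-fold lower number from compound 2 to compound 4 (0.78 log units; beyond the scatter). The simplest comparison is bromo in place of hydrogen on an aromatic carbon, which gives a 4.5-fold lower number from compound 3 to compound 4 (0.65 log units; beyond the scatter), so adding this one group to the plain phenyl is enough for a step beyond the scatter. Nothing available explains why the bromo compound stands apart from the others.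

The compounds shown leave open whether bromine elsewhere on the phenyl ring would give a similar number. They also leave open whether chloro, methoxy or an amine could replace bromo with the same result.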